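The compounds below may be only part of what the source reports. "The series", "measured", "known", "first", "only" and "open" are said of these compounds alone.

Measured so far in an assay on isolated protein for inhibition of acyl-CoA:cholesterol acyltransferase (Oryctolagus cuniculus); on this read-out higher numbers stand for weaker inhibition and lower numbers for stronger inhibition:
- compound 1, `CCCCCCCCCCCCCCc1ccc(NC(=O)Nc2c(C(C)C)cccc2C(C)C)cc1`: 500 nM
- compound 2, `CCCCCCCCCCCCCc1ccc(NC(=O)Nc2c(C(C)C)cccc2C(C)C)cc1`: 11 nM
- compound 3, `CCCCCCCCCCc1ccc(NC(=O)Nc2c(C(C)C)cccc2C(C)C)cc1`: 13 nM

All three share one core and differ only in the length of the saturated chain on the aryl urea. Compound 2 and compound 3 sit close together: a 1.2-fold higher number from compound 2 to compound 3 (0.07 log units; within the scatter), the difference being (hydrogen in place of propyl on a saturated chain carbon, ten or more bonds along the chain from an aromatic carbon). Compound 1 stands apart: a 45-fold higher number from compound 2 to compound 1 (1.66 log units; beyond the scatter), the difference being (methyl in place of hydrogen on a saturated chain carbon, ten or more bonds along the chain from an aromatic carbon). Read the other way, a 38-fold lower number from compound 1 to compound 3 (1.59 log units; beyond the scatter). So the chain tolerates a wide span of lengths without a change in this assay, and only the longest chain measured so far gives a markedly higher number.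

Compound 4, `CCCCCCCCCCCc1ccc(NC(=O)Nc2c(C(C)C)cccc2C(C)C)cc1`, has not yet been measured. It differs from compound 3 by methyl in place of hydrogen on a saturated chain carbon, ten or more bonds along the chain from an aromatic carbon. This is the same change as that from compound 2 to compound 1, and the place is described in identical words, so the two changes are the same. That earlier step was large. Here, however, compound 4 lands at a chain length between compound 3 and compound 2, two compounds whose numbers lie within the scatter of each other, so a small step is expected rather than a repeat of the large one. The step expected from compound 3 to compound 4 in this assay is a 1.1-fold lower number from compound 3 to compound 4 (0.03 log units; within the scatter), resting on a 1.2-fold higher number from compound 2 to compound 3 (0.07 log units; within the scatter) as the nearer comparison. Compound 4 is therefore estimated at 12 nM, with a range from 5 nM to 40 nM.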

Compound 4, half-maximal inhibitory concentration: 9 nM
For compound 4 the middle estimate is 1.3-fold (0.12 log units) above the measured one; measured number inside the range.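

The new step (a 1.4-fold lower number from compound 3 to compound 4 (0.16 log units; within the scatter)) does not repeat the earlier step for the same change, so in this assay methyl in place of hydrogen at this place on the chain cannot be carried as a fixed increment from one chain length to another: the same change on two cores in this assay, a 45-fold higher number (1.66 log units; beyond the scatter) from compound 2 to compound 1 and a 1.4-fold lower number (0.16 log units; within the scatter) from compound 3 to compound 4, 66-fold (1.82 log units) apart, beyond the scatter of two such steps.

Hydrogen in place of propyl also fails to carry over, with compound 1 again the one that stands apart (a 56-fold lower number from compound 1 to compound 4 (1.74 log units; beyond the scatter)), while compound 2 and compound 4 remain within the scatter of each other (a 1.2-fold lower number from compound 2 to compound 4 (0.09 log units; within the scatter)): the same change on two cores in this assay, a 1.2-fold higher number (0.07 log units; within the scatter) from compound 2 to compound 3 and a 56-fold lower number (1.74 log units; beyond the scatter) from compound 1 to compound 4, 66-fold (1.82 log units) apart, beyond the scatter of two such steps.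

The whole disagreement rests on compound 1 alone, so these data show that the size of the step depends on the chain it is made on, but they give neither a cause for the jump nor a general rule for chain length beyond these four compounds.

Still open, on these data alone, is how the number behaves for a chain shorter than that of compound 3 or longer than that of compound 1, and whether the jump at compound 1 belongs to that one chain length or continues. Also open is whether a hydroxyl or a carboxylic acid on the chain would be tolerated in the same way as the plain saturated chains shown here.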